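Compound 3 to compound 4: a step at the limit

The source may hold more compounds than are shown below. What is called first, only, known or untested is meant among the compounds shown, and "the series" means these compounds.

Measured in a functional assay on MDA-MB-436 cells (Homo sapiens) for antiproliferative activity, read by MTT assay, with a stated time of 24 h; a lower number here means a stronger inhibitor, a higher number a weaker inhibitor:
compound 1 `O=C(O)CC(NC(=O)c1c(Cl)cccc1Cl)c1ccccc1`: > 100000 nM
compound 2 `N#Cc1ccc(S(=O)(=O)NC(CC(=O)O)c2ccccc2F)cc1`: 77700 nM
compound 3 `O=C(O)CC(NC(=O)c1cccc(Br)c1)c1ccc(Cl)cc1Cl`: > 100000 nM

Compound 3 gives > 100000 nM, which is a limit of this assay and not a number. The three readings so far are marked by the limit of > 100000 nM in this assay, at which 2 of the 3 values shown sit. Compound 2 alone gives a number, 77700 nM.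

Compound 4 `O=C(O)CC(NC(=O)c1c(Cl)cccc1Cl)c1ccc(Cl)cc1Cl` departs from compound 3 in one place: 2,6-dichlorophenyl in place of 3-bromophenyl on a carbonyl carbon. It carries 2,6-dichlorophenyl in place of 3-bromophenyl on a carbonyl carbon. Compound 1, which bears the same 2,6-dichlorophenyl on a carbonyl carbon, gives > 100000 nM, also a limit.

Going by the values given here, no two measured compounds differ in one place, so no measured step is available as a guide. No step beyond the scatter is expected in this assay, and another limit reading is the likeliest outcome. The estimated change is a number no higher from compound 3 to compound 4 (the limit leaves the size open). For compound 4 the expected value is 100000 nM, with an estimated range of 50000 nM to 200000 nM.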

Compound 4, half-maximal inhibitory concentration: > 100000 nM
Compound 4 was reported as a limit; the forecaster's own chance of this, stated with the estimate: 75%; the middle value lies on the limit itself.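

Compound 4 gives > 100000 nM, a limit and not a number. No step can be read from compound 3 or compound 1 to compound 4, since all three compounds sit at the same limit: the limit of > 100000 nM in this assay, at which 3 of the 4 values shown sit.

As far as these compounds go, whether either change alters activity at all, and by how much, stays open.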